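A few compounds are considered here, and "the series" means these few. Any claim that something is new, unique, unknown or untested is made for them only; others in the source may bear on it.

Measured in a functional assay on HCT-116 cells (Homo sapiens) for inhibition, read by MTT assay, with a stated time of 48 h; a higher number here means a weaker inhibitor, a lower number a stronger inhibitor:
- compound 1 `COc1ccc(CSc2nnc(-c3cc(OC)c(OC)c(OC)c3)n2-c2ccc(OC)cc2)cc1`: 49600 nM
- compound 2 `COc1ccc(-n2c(SCc3ccc(F)cc3)nnc2-c2cc(OC)c(OC)c(OC)c2)cc1`: 38700 nM
- compound 3 `COc1ccc(-n2c(SCC(=O)C3CC3)nnc2-c2cc(OC)c(OC)c(OC)c2)cc1`: > 60000 nM, which is a limit of the assay and not a number

Compound 2 carries a number that cannot be told apart from that of compound 1, as a 1.3-fold lower number from compound 1 to compound 2 (0.11 log units; within the scatter) shows. Swapping fluoro for methoxy on that aromatic ring therefore leaves no measurable mark in this assay.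

The unmeasured compound 4 `CCOC(=O)CSc1nnc(-c2cc(OC)c(OC)c(OC)c2)n1-c1ccc(OC)cc1` keeps the shared core of compound 2 but changes the group on the sulfur chain: ethoxycarbonyl in place of 4-fluorophenyl on a saturated chain carbon bound to a sulfur. In words, ethoxycarbonyl stands in place of 4-fluorophenyl on a saturated chain carbon bound to a sulfur, so the aromatic ring of that group is lost.

The nearest guide is compound 3, where a carbonyl-bearing group, cyclopropylcarbonyl, replaces the same 4-fluorophenyl: an at least 1.5-fold higher number from compound 2 to compound 3 (0.19 log units; that floor lies within the scatter). The matching change from a 4-methoxyphenyl gives an at least 1.2-fold higher number from compound 1 to compound 3 (0.08 log units; that floor lies within the scatter). Both steps end on a limit, so they give only floors, and neither floor clears the scatter.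

A small move toward a weaker inhibitor therefore seems likely, and the expected step is a 1.4-fold higher number from compound 2 to compound 4 (0.15 log units; within the scatter). For compound 4 the estimated value is 55000 nM, expected to fall between 30000 nM and 100000 nM.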

Compound 4, half-maximal inhibitory concentration: > 60000 nM
Compound 4 ended at the assay's limit; the forecaster's own chance of this, stated with the estimate: 50%; middle value at least 1.0-fold (0.03 log units) away from the limit.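

Compound 4 gives a limit and not a number in this assay, so a second group without an aromatic ring, ethoxycarbonyl, ends where cyclopropylcarbonyl ended in compound 3, while the two compounds that keep an aromatic ring at this place on the sulfur chain both give numbers. The readable steps are an at least 1.5-fold higher number from compound 2 to compound 4 (0.19 log units; that floor lies within the scatter) and an at least 1.2-fold higher number from compound 1 to compound 4 (0.08 log units; that floor lies within the scatter), and both are only floors, so they hint at a weaker inhibitor without showing one. The step that swaps ethoxy for cyclopropyl on the carbonyl carbon cannot be read, because both of its ends stand at the same limit: the limit of > 60000 nM in this assay, at which 2 of the 4 values shown sit.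

As far as these compounds go, how far compound 3 and compound 4 really lie from compound 1 and compound 2 stays unknown, so the real size of losing the aromatic ring remains open, and so does any ranking of the two carbonyl-bearing groups. Also open, from the compounds shown here alone, is whether a carboxylic acid, an amine or a longer carbon chain at this place on the sulfur chain would bring the value back inside the range of the assay.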